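This account rests on a few compounds, and the source may have more. Where it says the series, first, only, none or still open, it means among the compounds named here.

Measured compounds and values:

compound 1, `OCCn1cc2c(Nc3ccc(OC(F)(F)F)cc3)ncnc2n1`. In an ADME assay on BaF3 cells (Mus musculus) for cytotoxicity (on this read-out higher numbers stand for an effect only at larger amounts of compound and lower numbers for an effect already at smaller amounts), compound 1 gives > 10000 nM, which is a limit of the assay and not a number.
compound 2, `CCn1ncc2c(Nc3ccc(OC(F)(F)F)cc3)ncnc21`. In this assay compound 2 gives > 10000 nM, again a limit of the assay.
compound 3, `CCn1cc2c(Nc3ccc(OC(F)(F)F)cc3)ncnc2n1`. In this assay compound 3 gives > 10000 nM, also a limit of the assay.

Compound 2 and compound 3 are built from the same atoms joined differently; the difference between the two cores is not broken down here. Compound 3 and compound 1 differ in one place, (hydroxy in place of hydrogen on a saturated chain carbon, two bonds along the chain from an aromatic nitrogen), and the resulting step that the two limits leave unreadable from compound 3 to compound 1 cannot be read, since both ends sit at a limit. Going by the values given here, all that the measured set shows is the limit of > 10000 nM in this assay, at which 3 of the 3 values shown sit; no compound in it reaches a number in this assay.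

The unmeasured compound 4, `OCCn1ncc2c(Nc3ccc(OC(F)(F)F)cc3)ncnc21`, carries the same change relative to compound 2 that compound 1 carries relative to compound 3: hydroxy in place of hydrogen on a saturated chain carbon, two bonds along the chain from an aromatic nitrogen. The place of the change is the same in both pairs.

For compound 4 the step that the limit leaves unreadable from compound 2 to compound 4 is expected to be small or unreadable, resting on the step from compound 3 to compound 1, a step that the two limits leave unreadable from compound 3 to compound 1, which did not move the read-out off the limit, and on (the limit of > 10000 nM in this assay, at which 3 of the 3 values shown sit). Compound 4 is therefore estimated at 15000 nM, with a range from 5000 nM to 40000 nM, and it is expected that the assay will most likely again report only a limit.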

Compound 4, half-maximal effective concentration: > 10000 nM
Compound 4: no number, only a limit; the forecaster's own chance of this, stated with the estimate: 85%; the middle value does not contradict the limit.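

In this assay compound 4 gives > 10000 nM, which is a limit of the assay and not a number. Going by these compounds alone, compound 2 sits at a limit too, so the step between compound 2 and compound 4 cannot be read and no new step results. The compounds shown leave open at what concentration any of them would give a number, and whether the hydroxy change shifts it; they offer only this: the limit of > 10000 nM in this assay, at which 4 of the 4 values shown sit.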